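The source may hold more compounds than are shown below. What is called first, only, known or untested is meant among the compounds shown, and "the series" means these compounds.

Working notes on the dibenzyloxy series.

Compound 1 `O=C1NC(O)(CCn2cc(-c3ccccc3)nn2)C(OCc2ccccc2)=C1OCc1ccccc1` gives, in a functional assay on PC-3 cells (Homo sapiens) for antiproliferative activity, read by MTT assay, with a stated time of 24 h (on this read-out higher numbers stand for weaker inhibition and lower numbers for stronger inhibition), a value that is only a limit of the assay: compound 1 gives > 100000 nM. Compound 1 therefore stands at the limit of > 100000 nM in this assay, at which 1 of the 2 values shown sits, so no number is known for it, only that it sits beyond the range measured. The dimethoxy analogue, compound 2 `COC1=C(OC)C(O)(CCn2cc(-c3ccccc3)nn2)NC1=O`, gives in this assay a measured figure; compound 2 gives 35300 nM. Within the data shown here, no step between these two is computed here, and the pair shows only a limit against a number.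

Compound 3 `Cc1ccc(-c2cn(CCC3(O)NC(=O)C(OCc4ccccc4)=C3OCc3ccccc3)nn2)cc1` differs from compound 1 by methyl in place of hydrogen on an aromatic carbon. Among the measured compounds shown here, with compound 1 already at the limit and no measured step to lean on, the expected step from compound 1 to compound 3 in this assay is none beyond the scatter, a number no higher from compound 1 to compound 3 (the limit leaves the size open). Compound 3 is thus estimated at 100000 nM, within 40000 nM to 250000 nM, with a real chance that only a limit is again reported.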

Compound 3, half-maximal inhibitory concentration: 84200 nM
Beside the measured number, compound 3's estimate is 1.2-fold (0.07 log units) above it; the measured number falls inside the stated range.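

In this assay, methyl in place of hydrogen on an aromatic carbon, para to a large group, gives the dibenzyloxy series its first measured figure: compound 3 gives 84200 nM. On these data alone, the change from phenyl to 4-methylphenyl reads as an at least 1.1-fold lower number from compound 1 to compound 3 (0.07 log units; that floor lies within the scatter), so only a floor is known for this step and its true size stays open. That floor rests on a limit, which is all that is known of compound 1: the limit of > 100000 nM in this assay, at which 1 of the 3 values shown sits.

The compounds shown leave open whether a methoxy group, a chlorine atom or a carboxylic acid at this place would move the number beyond the scatter. They also leave open what methyl at this place would do on the dimethoxy core of compound 2.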